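A few compounds are considered here, and "the series" means these few. Any claim that something is new, unique, unknown or untested is made for them only; others in the source may bear on it.

Compound 1 `Oc1cc(-c2ccc(Cl)cc2)nc2ncccc12`: 33900 nM
Compound 2 `Cc1cnc2nc(-c3ccc(Cl)cc3)cc(O)c2c1`: 6310 nM
Compound 3 `COc1ccccc1-c1cc(O)c2ccc(C)nc2n1`: > 100000 nM (a limit)

In a functional assay on 786-0 cells (Homo sapiens) (on this read-out higher numbers stand for weaker inhibition of growth and lower numbers for stronger inhibition of growth), compound 2 has the lowest of the two actual numbers, with compound 1 as its nearest neighbour. The two are linked by a 5.4-fold lower number from compound 1 to compound 2 (0.73 log units; beyond the scatter). Compound 3 gives > 100000 nM, which is a limit of the assay and not a number.

The next compound, compound 4 `Cc1cnc2nc(-c3ccc(F)cc3)cc(O)c2c1`, is made from compound 2 by one change: fluoro in place of chloro on an aromatic carbon. Fluoro takes the place of chloro on an aromatic carbon, para to a large group. Among the measured compounds shown here, no measured step covers this swap. The only one available, a 5.4-fold lower number from compound 1 to compound 2 (0.73 log units; beyond the scatter), is a different change, methyl in place of hydrogen, so it gives no direct guide to size or direction. For the measured compounds named here, compound 3 differs from the others in more than one place and offers no measured step. With so little to go on, only a small shift is expected, and the estimated step is a 1.6-fold higher number from compound 2 to compound 4 (0.20 log units; within the scatter), leaning toward a higher number but not clearly beyond the scatter. For compound 4 the estimated value is 10000 nM, with an expected range from 3000 nM to 35000 nM.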

Compound 4, concentration for 50% growth inhibition: 32400 nM
For compound 4 the middle estimate is 3.2-fold (0.51 log units) below the measured one; low and high end bracket the measured number.
By their numbers in this assay, from the lowest: compound 2; then compounds 4 and 1 (each within the scatter of the next). At a limit, above all of these: compound 3.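

In this assay the swap of chloro for fluoro, on an aromatic carbon para to a large group, gives a 5.1-fold higher number from compound 2 to compound 4 (0.71 log units; beyond the scatter) and so shows that this position is sensitive to which halogen it carries. The earlier pair showed only a change on the shared core, a 5.4-fold lower number from compound 1 to compound 2 (0.73 log units; beyond the scatter) and, with this new step also beyond the scatter, both places now register a change in the number. Nothing at hand bears on why this swap has such an effect.

The compounds shown leave open how an amine or a trifluoromethyl group at this position would read in this assay and how hydrogen there would compare with either halogen. They also leave open whether fluoro in place of chloro gives a similar step on the core of compound 1.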